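This account rests on a few compounds, and the source may have more. Where it says the series, first, only, none or still open, it means among the compounds named here.

Compound 1 `O=C(c1ccc(F)cc1)N1CC(c2nc(-c3cccc(Cl)c3)no2)C1` gives in an assay on HEK293 cells for positive allosteric modulation of metabotropic glutamate receptor 5 (Homo sapiens), read by FLIPR (on this read-out higher numbers stand for an effect only at larger amounts of compound and lower numbers for an effect already at smaller amounts), only a limit, > 10000 nM. Compound 2 `O=C(C1CCC1)N1CC(c2nc(-c3cccc(Cl)c3)no2)C1` likewise gives only a limit, > 10000 nM. Compound 3 `O=C([C@H]1CC2CCC1C2)N1CC(c2nc(-c3cccc(Cl)c3)no2)C1` gives 74 nM.

Among the measured compounds shown here, compound 3 thus holds the only real number in this small set. The two other entries are limits (the limit of > 10000 nM in this assay, at which 2 of the 3 values shown sit). Compound 4 `COC1CCCN(C(=O)N2CC(c3nc(-c4cccc(Cl)c4)no3)C2)C1` has not yet been measured. It differs from compound 3 by a group of 8 heavy atoms (6 carbon, 1 nitrogen, 1 oxygen; one six-membered non-aromatic ring with 1 hetero atom) in place of a group of 7 heavy atoms (7 carbon; 2 five-membered non-aromatic rings of carbon only), on a carbonyl carbon. For the measured compounds named here, two measured steps touch this same carbonyl position: an at least 130-fold lower number from compound 1 to compound 3 (2.13 log units; beyond the scatter) and an at least 130-fold lower number from compound 2 to compound 3 (2.13 log units; beyond the scatter). Both show that the bicyclic group went with a far lower number than either a four-membered ring or an aromatic ring at that spot. Exchanging the bicyclic group for a six-membered ring with one hetero atom is therefore expected to raise the number, though by an uncertain amount. For compound 4 the estimate is 1500 nM, between 150 nM and 10000 nM, meaning an expected 20-fold higher number from compound 3 to compound 4 (1.31 log units; beyond the scatter).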

Compound 4, half-maximal effective concentration: > 10000 nM
Compound 4 ended at the assay's limit; the forecaster's own chance of this, stated with the estimate: 30%; at least 6.6-fold (0.82 log units) between middle value and limit.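

Replacing the bicyclic carbon group with 3-methoxypiperidin-1-yl on this carbonyl carbon gives an at least 130-fold higher number from compound 3 to compound 4 (2.13 log units; beyond the scatter). A six-membered non-aromatic ring with a hetero atom thus joins 4-fluorophenyl and cyclobutyl at the limit, leaving the bicyclic group as the only one shown here with a real number. The steps from compound 1 and compound 2 to compound 4 cannot be read because both ends of each are limits: the limit of > 10000 nM in this assay, at which 3 of the 4 values shown sit.

The compounds shown leave open whether the methoxy group, the ring nitrogen or the ring shape goes with this large step. Plain piperidin-1-yl or cyclohexyl at this carbonyl carbon would help separate these.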